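Swapping an isopropylphenyl for a pyridinyl on a shared core

The source may hold more compounds than are shown below. What is called first, only, known or untested is meant among the compounds shown, and "the series" means these compounds.

For the measured compounds named here, compound 3 `CC(C)c1ccc(C2C(C#N)=C(N)Oc3c2c(-c2ccccc2)nn3C)cc1` is the only compound here with an actual number in a functional assay on NCI-H2122 cells (Homo sapiens) for inhibition, read by microscopy, with a stated time of 10 days; on this read-out lower numbers stand for stronger inhibition and higher numbers for weaker inhibition: compound 3 gives 5400 nM. Compound 1 `Cn1nc(-c2ccccc2)c2c1OC(N)=C(C#N)C2c1ccc(F)cc1` reaches only the limit of the assay, giving > 10000 nM. Compound 2 `COc1ccc(C2C(C#N)=C(N)Oc3c2c(-c2ccccc2)nn3C)cc1` likewise stops at the limit, giving > 10000 nM. The measured steps are therefore floors rather than sizes: an at least 1.8-fold lower number from compound 1 to compound 3 (0.26 log units; that floor lies within the scatter), an at least 1.8-fold lower number from compound 2 to compound 3 (0.26 log units; that floor lies within the scatter), while a step that the two limits leave unreadable from compound 1 to compound 2. Compound 4 `Cn1nc(-c2ccccc2)c2c1OC(N)=C(C#N)C2c1cccnc1` differs from compound 3 by pyridin-3-yl in place of 4-isopropylphenyl on a saturated ring carbon. This removes the isopropyl group that set compound 3 apart, so the number for compound 4 is expected to rise, by a 2.2-fold higher number from compound 3 to compound 4 (0.35 log units; beyond the scatter), quite possibly back to the limit of > 10000 nM in this assay, at which 2 of the 3 values shown sit. The estimate for compound 4 is 12000 nM, within 4000 nM to 40000 nM.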

Compound 4, half-maximal inhibitory concentration: > 10000 nM
Compound 4 ended at the assay's limit; the forecaster's own chance of this, stated with the estimate: 65%; the middle value is on the limit's open side.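

At this saturated ring carbon, pyridin-3-yl brings in a ring nitrogen and loses the isopropyl group, yet in this assay the result can be stated only as an at least 1.8-fold higher number from compound 3 to compound 4 (0.26 log units; that floor lies within the scatter). The steps among compound 1, compound 2 and compound 4 cannot be read. Of the four aryl groups shown at this carbon, only 4-isopropylphenyl gives an actual number, and the rest stop at a limit: the limit of > 10000 nM in this assay, at which 3 of the 4 values shown sit.

Still open, going by these compounds, is whether a phenyl ring carrying a longer chain or a carboxylic acid in place of the isopropyl would lower the number beyond the scatter. On these data alone, whether an amine there would do so is equally open.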